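A few compounds are considered here, and "the series" means these few. Any claim that something is new, unique, unknown or untested is made for them only; others in the source may bear on it.

In a functional assay on NCI-H1650 cells (Homo sapiens) for cytotoxicity, read by MTT assay, with a stated time of 48 h (a lower number here means a stronger inhibitor, a higher number a weaker inhibitor), compound 1 `CC(C)COc1ccc2c(Cl)ccnc2c1` gives 2100 nM, the lowest of the three numbers, although compound 2 `CCOc1ccc2c(NCCN(C)C)ccnc2c1` with 3490 nM and compound 3 `CCOc1ccc2c(NCCCN(C)C)ccnc2c1` with 3830 nM both lie within the scatter of that value. For the measured compounds named here, the only measured step, a 1.1-fold higher number from compound 2 to compound 3 (0.04 log units; within the scatter), concerns the chain two bonds from a nitrogen on an aromatic ring, not the chain bound to the oxygen. Compound 4 `C=CCOc1ccc2c(Cl)ccnc2c1` differs from compound 1 by vinyl in place of isopropyl on a saturated chain carbon bound to an oxygen on an aromatic ring. Going by the values given here, no measured pair touches this position, so nothing in the data points to a shift beyond the scatter. Compound 4 is therefore expected to give about 2100 nM, most likely between 900 nM and 5000 nM. That expected step, no change at the digits printed from compound 1 to compound 4 (within the scatter), is none beyond the scatter.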

Compound 4, half-maximal inhibitory concentration: 2280 nM
Estimate against measurement, compound 4: 1.1-fold (0.04 log units) below, within the range that was stated.
By their numbers in this assay, from the lowest: compounds 1, 4, 2 and 3 (each within the scatter of the next).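

For the compounds shown here, the step to allyloxy, a 1.1-fold higher number from compound 1 to compound 4 (0.04 log units; within the scatter), is the first measured change on the chain bound to the oxygen, and in this assay it stays within the scatter. For this pair, isopropyl can give way to vinyl, with its double bond, without a shift beyond the scatter. No data at hand explain this result.

As far as these compounds go, whether a longer chain, an amine or a carboxylic acid on that chain would move the number remains open. So does whether the same change would behave alike in compound 2 or compound 3.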